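A few compounds are considered here, and "the series" means these few. Any claim that something is new, unique, unknown or untested is made for them only; others in the source may bear on it.

Measured compounds in a functional assay on A549 cells (Homo sapiens) for cytotoxicity, read by MTT assay, with a stated time of 72 h; on this read-out lower numbers stand for stronger inhibition and higher numbers for weaker inhibition:
compound 1, `CN(C)CCn1cnnc1-c1cc(Oc2ccc(NC(=O)N/N=C/c3ccccc3)cc2F)ccn1`: 1860 nM.
compound 2, `CN(C)CCn1cnnc1-c1cc(Oc2ccc(NC(=O)N/N=C/c3cc(Br)c(O)c(Br)c3)cc2F)ccn1`: > 100000 nM, a limit of the assay rather than a number.
compound 3, `COc1ccc(/C=N/NC(=O)Nc2ccc(Oc3ccnc(-c4nncn4CCN(C)C)c3)c(F)c2)cc1O`: > 100000 nM, likewise a limit of the assay.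

Going by the values given here, compound 1 is therefore the only compound of the set with a number in this assay; the other two values sit at the limit of > 100000 nM in this assay, at which 2 of the 3 values shown sit. Compound 4, `COc1cc(/C=N/NC(=O)Nc2ccc(Oc3ccnc(-c4nncn4CCN(C)C)c3)c(F)c2)ccc1O`, is not yet measured. It differs from compound 1 in one place: 4-hydroxy-3-methoxyphenyl in place of phenyl on a carbon with a double bond to nitrogen. Among the compounds with values here, two measured steps bear on this change, each putting a substituted phenyl on the same carbon in place of phenyl: an at least 53-fold higher number from compound 1 to compound 2 (1.73 log units; beyond the scatter) and an at least 53-fold higher number from compound 1 to compound 3 (1.73 log units; beyond the scatter). Between compound 2 and compound 3, a step that the two limits leave unreadable from compound 2 to compound 3, so the two substituted phenyls cannot be told apart. The group entering compound 4 is the 4-hydroxy-3-methoxyphenyl counterpart of the 3-hydroxy-4-methoxyphenyl of compound 3, carrying the same hydroxy and methoxy. Both substituted phenyls so far drove the value to the limit, so a large rise in the number is expected for compound 4, a 43-fold higher number from compound 1 to compound 4 (1.63 log units; beyond the scatter), with a real chance that only a limit is again reported. The expected value for compound 4 is 80000 nM, in the range 8000 nM to 300000 nM.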

Compound 4, half-maximal inhibitory concentration: > 100000 nM
Compound 4: no number, only a limit; the forecaster's own chance of this, stated with the estimate: 65%; at least 1.2-fold (0.09 log units) between middle value and limit.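

In this assay compound 4 gives > 100000 nM, again a limit of the assay and not a number. On the carbon with a double bond to nitrogen, 4-hydroxy-3-methoxyphenyl in place of phenyl gives an at least 53-fold higher number from compound 1 to compound 4 (1.73 log units; beyond the scatter), so exchanging the hydroxy and methoxy of the 3-hydroxy-4-methoxyphenyl of compound 3 does not restore a measurable value, and the steps linking compound 4 to compounds 2 and 3 cannot be read, as both ends of each are limits. Among the compounds shown, only the plain phenyl of compound 1 gives a number, and none of the three substituted phenyls goes against this: the limit of > 100000 nM in this assay, at which 3 of the 4 values shown sit.

On these data alone, whether compounds 2, 3 and 4 differ from one another remains open, since their limits hide any true values. Also open, as far as these compounds go, is whether the loss of a measurable value needs two substituents on the phenyl or follows from a single one, a question that a simple 4-methoxyphenyl, 4-hydroxyphenyl or 4-aminophenyl on the same carbon would address.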